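The source may report more compounds than this note shows. Statements on the series, on what has been measured and on what is new or still open speak of the compounds shown alone.

Measured compounds:
compound 1, `NCCCOc1ccccc1C(=O)N(Cc1ccc(OCCCN=C(N)N)cc1)c1nc2ccc(Oc3ccc(O)cc3)cc2s1`: 1780 nM
compound 2, `NCCCOc1ccc(CNC(c2ccccc2)c2ccccc2)cc1`: > 100000 nM

Of the compounds shown here, two have been measured in an assay on isolated protein for inhibition of Voltage-dependent N-type calcium channel subunit alpha-1B (Rattus norvegicus); a higher number here means that more compound is needed for the effect, a lower number that less compound is needed. Compound 1, `NCCCOc1ccccc1C(=O)N(Cc1ccc(OCCCN=C(N)N)cc1)c1nc2ccc(Oc3ccc(O)cc3)cc2s1`, gives 1780 nM. Compound 2, `NCCCOc1ccc(CNC(c2ccccc2)c2ccccc2)cc1`, is reported only as a limit of the assay, > 100000 nM, and no number is known for it. The point where compound 2 sits is the limit of > 100000 nM in this assay, at which 1 of the 2 values shown sits, the edge of what the assay can report.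

Compound 3, `NC(N)=NCCCOc1ccc(CNC(c2ccccc2)c2ccccc2)cc1`, differs from compound 2 in one place: a group of 4 heavy atoms (1 carbon, 3 nitrogen; no ring) in place of one nitrogen atom, on a saturated chain carbon, three bonds along the chain from an oxygen on an aromatic ring. Among the compounds with values here, no measured pair shows this change on its own, so the size of the step cannot be read from the data; compound 1 carries the entering group too, but on a different core, and its value is no guide to the step. Even a sizeable gain could leave compound 3 near the limit.

Compound 3 is expected to come in at 50000 nM, within a range of 5000 nM to 300000 nM. The step is estimated as a gain, an at least 2.0-fold lower number from compound 2 to compound 3 (0.30 log units; that floor lies within the scatter), with the chance that the assay again returns only a limit left open.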

Compound 3, half-maximal effective concentration: 23000 nM
Estimate against measurement, compound 3: 2.2-fold (0.34 log units) above; the measured number falls inside the stated range.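

In this assay, within the data shown here, the change at this position has a readable effect for the first time: replacing the amino group with the group of 4 heavy atoms (1 carbon, 3 nitrogen), on a saturated chain carbon, three bonds along the chain from an oxygen on an aromatic ring, gives an at least 4.3-fold lower number from compound 2 to compound 3 (0.63 log units; beyond the scatter). With this group in place, the core shared by the two compounds yields a real number rather than a limit, as compound 3 gives 23000 nM, and the step lies beyond the usual scatter. The printed step is only a floor and its full size stays unknown, because the starting point is a limit and not a number: the limit of > 100000 nM in this assay, at which 1 of the 3 values shown sits.

The compounds shown do not tell whether a longer chain carrying the same group, or a dimethylamino group at the same place, would shift the value in this assay as far or further. Compound 1 carries the entering group as well, but it differs from compound 3 in more than one place, so it cannot show whether the same exchange would have a similar effect on its own core.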